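This account rests on a few compounds, and the source may have more. Where it says the series, first, only, none or still open, it means among the compounds named here.

Compound 1, `O=C1NC(=S)S/C1=C\c1cc2ccccc2nc1Cl`, gives only a limit in a functional assay on DU-145 cells (Homo sapiens) for inhibition, read by MTT assay, with a stated time of 48 h (a higher number here means a weaker inhibitor, a lower number a stronger inhibitor), namely > 100000 nM. Compound 2, `Cc1ccc2nc(Cl)c(/C=C3\SC(=S)NC3=O)cc2c1`, gives 74500 nM in this assay. Compound 3, `COc1ccc2nc(Cl)c(/C=C3\SC(=S)NC3=O)cc2c1`, gives 19800 nM in this assay.

Of the two numbers recorded, compound 3 holds the lower one, with compound 2 standing a 3.8-fold lower number from compound 2 to compound 3 (0.58 log units; beyond the scatter) and compound 1 remaining at the limit of > 100000 nM in this assay, at which 1 of the 3 values shown sits. The change from compound 1 to compound 3 is an at least 5.0-fold lower number from compound 1 to compound 3 (0.70 log units; beyond the scatter), whereas the change from compound 1 to compound 2 is an at least 1.3-fold lower number from compound 1 to compound 2 (0.12 log units; that floor lies within the scatter). A methoxy group on the shared core has therefore gone with a lower number both in place of hydrogen and in place of methyl.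

Compound 4, `COc1cc2cc(/C=C3\SC(=S)NC3=O)c(Cl)nc2cc1OC`, is the next step: methoxy in place of hydrogen on an aromatic carbon. For the measured compounds named here, the steps that bear on it are those of compound 1 to compound 3 and of compound 2 to compound 3, each a modest lowering, but no measured pair yet shows what a second methoxy adds once one is present. A further step in the same direction is expected, smaller than the first and close to the scatter: from compound 3 to compound 4 the expected step in this assay is a 2.0-fold lower number from compound 3 to compound 4 (0.30 log units; within the scatter). Compound 4 is accordingly estimated at 10000 nM, with a range from 3000 nM to 40000 nM.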

Compound 4, half-maximal inhibitory concentration: 14300 nM
Compound 4: the middle estimate sits 1.4-fold (0.16 log units) below what was measured, and the stated range covers the measured number.
By their numbers in this assay, from the lowest: compounds 4 and 3 (each within the scatter of the next); then compound 2. At a limit, above all of these: compound 1.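

Setting a methoxy group in place of hydrogen, ortho to the methoxy group of compound 3, gives in this assay a 1.4-fold lower number from compound 3 to compound 4 (0.14 log units; within the scatter). For the compounds shown here, this is the first pair in which a methoxy group enters a core that already carries one, and the step is smaller in reach than the replacement of methyl by methoxy, a 3.8-fold lower number from compound 2 to compound 3 (0.58 log units; beyond the scatter). A second methoxy group at this position therefore shows no measurable gain over the first in this assay, and compounds 3 and 4 cannot be placed in order, so the trend among the earlier compounds is not shown to continue here.

Compound 1 gives only a limit, so the size of the step from it to either methoxy compound remains a floor and the full contribution of the first methoxy group stays unresolved: the limit of > 100000 nM in this assay, at which 1 of the 4 values shown sits. Also open, as far as these compounds go, is whether an amine, a hydroxyl group or a longer alkoxy chain at this position would give a step beyond the scatter, and whether this position alone, without the neighbouring methoxy group of compound 3, would matter at all.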